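Swapping the ring on the amide-type nitrogen of compound 1

This account rests on a few compounds, and the source may have more. Where it says the series, first, only, none or still open, it means among the compounds named here.

Measured compounds:
compound 1, `COc1ccc(C)cc1N1C(=O)CSC1c1cccc(C(=O)NCCCCc2ccccc2)c1`, 300 nM
compound 2, `Cc1ccnc(N2C(=O)CSC2c2cccc(C(=O)NCCCCn3cccn3)c2)c1`, 19.6 nM

Of the compounds shown here, two have been tested in a functional assay on HOS-TE85 cells (Homo sapiens) for inhibition, read by CCK-8 assay, with a stated time of 72 h; a lower number here means a stronger inhibitor, a higher number a weaker inhibitor. Compound 1 gives 300 nM, the higher of the two numbers. Compound 2 gives 19.6 nM, a gap that lies beyond the scatter of the method; the two compounds differ in more than one place, so nothing is said here about which part of the change accounts for it.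

Compound 3, `O=C(NCCCCc1ccccc1)c1cccc(C2SCC(=O)N2c2ccccc2F)c1`, has not yet been measured. It differs from compound 1 in a single place: 2-fluorophenyl in place of 2-methoxy-5-methylphenyl on an amide-type nitrogen in a ring. The rest of the shared core and the amide chain stay the same. Within the data shown here, with no single-change pair among the measured compounds to lean on, the size of this step is unknown. The author expects for compound 3 a number close to that of compound 1, with the step of a 1.2-fold lower number from compound 1 to compound 3 (0.08 log units; within the scatter) estimated to stay within the usual scatter. The estimate for compound 3 in this assay is 250 nM, expected to fall between 80 nM and 800 nM.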

Compound 3, half-maximal inhibitory concentration: 34.1 nM
The estimate for compound 3 lay 7.3-fold (0.87 log units) above the measured number; measured number below the stated range.
By their numbers in this assay, from the lowest: compounds 2 and 3 (each within the scatter of the next); then compound 1.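

In this assay, among these compounds, the single change on the amide-type nitrogen, 2-fluorophenyl in place of 2-methoxy-5-methylphenyl, gives an 8.8-fold lower number from compound 1 to compound 3 (0.94 log units; beyond the scatter) with the amide chain and the rest of the shared core unchanged. Among the compounds shown here, the earlier compounds differed in more than one place, so this is the first sign that the group at this position can, on its own, move the number beyond the scatter. On this phenylbutyl amide chain, the 2-methoxy-5-methylphenyl group is therefore not needed for the lower number: the entering group has fewer heavy atoms, 7 against 9, and no hydrogen-bond acceptor, while the leaving group has one.

Because the change removes two substituents and adds a third, the compounds shown leave open whether the methoxy, the methyl or the fluorine accounts for the step, and how a plain phenyl, a 2-methoxyphenyl or a 2-chlorophenyl group would read at this position. No measurement offered here gives a reason for the size of the step.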